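Fluorine on the outer ring and tolerated concentration

A few compounds are considered here, and "the series" means these few. Any claim that something is new, unique, unknown or untested is made for them only; others in the source may bear on it.

Of the compounds shown here, three have been tested in a functional assay on MT4 cells (Homo sapiens) for cytotoxicity, read by MTT assay, with a stated time of 5 days; a higher number here means that more compound is tolerated, a lower number that less compound is tolerated. Compound 2 `N#Cc1ccc(Nc2nccc(Oc3ccc(-c4ccc(C#N)cc4)cc3F)n2)cc1` carries a 4-cyanophenyl group on its fluoro-bearing core; in this assay compound 2 reaches only a limit, > 307000 nM. Compound 1 `N#Cc1ccc(Nc2nccc(Oc3ccc(-c4ccc(C#N)c(F)c4)cc3F)n2)cc1` differs by fluoro in place of hydrogen on an aromatic carbon, and in this assay compound 1 also reaches only a limit, > 294000 nM. Compound 3 `Cc1cc(-c2ccc(C#N)cc2)ccc1Oc1ccnc(Nc2ccc(C#N)cc2)n1` differs from compound 2 by methyl in place of fluoro on an aromatic carbon, and in this assay compound 3 again reaches only a limit, > 310000 nM. Because each value sits at a limit, as the limit of > 294000 nM in this assay, at which 1 of the 3 values shown sits, the limit of > 307000 nM in this assay, at which 1 of the 3 values shown sits, and the limit of > 310000 nM in this assay, at which 1 of the 3 values shown sits, show, a step that the two limits leave unreadable from compound 2 to compound 1 and a step that the two limits leave unreadable from compound 2 to compound 3.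

Compound 4 `Cc1cc(-c2ccc(C#N)cc2F)ccc1Oc1ccnc(Nc2ccc(C#N)cc2)n1` has not been measured. It differs from compound 3 by fluoro in place of hydrogen on an aromatic carbon. This is the same kind of change as that from compound 2 to compound 1, though the surroundings differ: there the fluoro sat ortho to a cyano group and meta to a large group, while in compound 4 it sits ortho to a large group and meta to a cyano group. Since adding fluoro to compound 2 gave compound 1 with > 294000 nM, a limit, the step to compound 4 is expected to be an at least 1.0-fold lower number from compound 3 to compound 4 (0.01 log units; that floor lies within the scatter). Compound 4 is therefore expected to be tolerated up to about 300000 nM in this assay, most likely again reported only as a limit.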

Compound 4, half-maximal cytotoxic concentration: > 296000 nM
Compound 4 gave a limit, no number; the forecaster's own chance of this, stated with the estimate: 85%; the middle value is on the limit's open side.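

In this assay compound 4 gives > 296000 nM, which is a limit and not a number. Going by these compounds alone, compound 3 also stands only at a limit, and no step from compound 3 to compound 4 can be read. The compounds shown leave open at what concentration any of compounds 1 to 4 harms the cells, and whether adding fluoro changes that concentration at all.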